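A few compounds are considered here, and "the series" means these few. Any claim that something is new, unique, unknown or untested is made for them only; others in the source may bear on it.

Series notes on an ADME assay on HOS cells (Homo sapiens) for cytotoxicity; on this read-out lower numbers stand for higher toxicity in this test and higher numbers for lower toxicity in this test. Compound 1 `CCN1CCN(c2cccc3nc(CN(C)[C@H]4CCCc5cccnc54)cn23)CC1` gives 3900 nM in this assay. Compound 2 `CN1CCN(c2cccc3nc(CN(C)[C@H]4CCCc5cccnc54)cn23)CC1` gives 4500 nM in this assay, and compound 3 `CN1CCN(c2cccc3nc(CN(C)[C@@H]4CCCc5cccnc54)cn23)CC1` gives 12600 nM in this assay. Compound 2 stands second highest of the three numbers, with compound 1 nearest and compound 3 furthest.

The step of a 1.2-fold higher number from compound 1 to compound 2 (0.06 log units; within the scatter), hydrogen in place of methyl on a saturated chain carbon bound to an amine nitrogen in a ring, stays within the scatter. The step of a 2.8-fold higher number from compound 2 to compound 3 (0.45 log units; beyond the scatter) is modest and beyond the scatter, and the fact that compounds 2 and 3 differ only in the configuration as drawn is all that separates that pair.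

Compound 4 `CN(C)[C@H]1CCN(c2cccc3nc(CN(C)[C@H]4CCCc5cccnc54)cn23)C1` is not yet measured. It differs from compound 2 in 3-(dimethylamino)pyrrolidin-1-yl in place of 4-methylpiperazin-1-yl on an aromatic carbon. Among the measured compounds shown here, of the measured steps, only the step of a 1.2-fold higher number from compound 1 to compound 2 (0.06 log units; within the scatter) touches the 4-methylpiperazin-1-yl, and it moved nothing beyond the scatter. For the measured compounds named here, the exchange in compound 4 is larger than that, yet no measured step gives a direction for it, so no shift beyond the scatter is expected in this assay. For compound 4 the expected step is no change at the digits printed from compound 2 to compound 4 (within the scatter). Compound 4 is therefore estimated at 4500 nM in this assay, with a range from 1800 nM to 11000 nM.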

Compound 4, half-maximal cytotoxic concentration: 2100 nM
Beside the measured number, compound 4's estimate is 2.1-fold (0.33 log units) above it, within the range that was stated.
By their numbers in this assay, from the lowest: compounds 4, 1 and 2 (each within the scatter of the next, the first and the last beyond it); then compound 3.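

In this assay, among the compounds shown here, the aromatic carbon next to the ring nitrogen now shows that its substituent can shift the read-out: the only earlier change in this group, on the 4-methylpiperazin-1-yl, stayed within the scatter, whereas replacing that ring with 3-(dimethylamino)pyrrolidin-1-yl gives a modest step beyond it (a 2.1-fold lower number from compound 2 to compound 4 (0.33 log units; beyond the scatter)). The same exchange made against 4-ethylpiperazin-1-yl stays within the scatter (a 1.9-fold lower number from compound 1 to compound 4 (0.27 log units; within the scatter)), so the effect of the new group is small and is resolved against only one of the two piperazines. Nothing measured here accounts for the step at this position.

As far as these compounds go, whether the step follows the five-membered ring or the dimethylamino group outside the ring stays open, and a 4-(dimethylamino)piperidin-1-yl on the same carbon would separate the two, while a morpholin-4-yl would test whether a second nitrogen is needed in this group at all. Also open, from the compounds shown here alone, are the role of the defined stereocentre in the pyrrolidine and whether the configuration at the saturated ring carbon of the shared core matters as much with this group as it does with 4-methylpiperazin-1-yl.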